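A few compounds are considered here, and "the series" means these few. Any claim that something is new, unique, unknown or untested is made for them only; others in the source may bear on it.

Series in a functional assay on A2780 cells (Homo sapiens) for antiproliferative activity, read by MTT assay, with a stated time of 48 h; on this read-out lower numbers stand for stronger inhibition and higher numbers for weaker inhibition:
- Compound 1 `COc1ccc(-c2cncc3[nH]c(=O)n(Cc4cc(OC)c(OC)c(OC)c4)c23)cc1O`: > 20000 nM, a limit
- Compound 2 `COc1ccc(-c2cncc3[nH]c(=O)n(Cc4cc(OC)c(OC)c(OC)c4)c23)cc1`: > 20000 nM, a limit
- Compound 3 `COc1ccc(-c2cc3c(cn2)[nH]c(=O)n3-c2cc(OC)c(OC)c(OC)c2)cc1`: 930 nM

For the measured compounds named here, compound 3 carries the only true number. Compounds 1 and 2 both stand at the limit of > 20000 nM in this assay, at which 2 of the 3 values shown sit.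

Compound 4 `COc1ccc(-c2cc3c(cn2)[nH]c(=O)n3-c2cc(OC)c(OC)c(OC)c2)cc1O` arises from compound 3 by hydroxy in place of hydrogen on an aromatic carbon, which reads as 4-methoxyphenyl to 3-hydroxy-4-methoxyphenyl. Going by the values given here, the only measured step on this change runs the opposite way, a step that the two limits leave unreadable from compound 1 to compound 2. It has no readable size, and compounds 1 and 2 also differ from compound 3 elsewhere.

The expected step is a 2.3-fold lower number from compound 3 to compound 4 (0.37 log units; beyond the scatter) in this assay, tentatively toward stronger inhibition, with no measured size behind it. Compound 4 is estimated at 400 nM, with an expected range of 40 nM to 3000 nM.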

Compound 4, half-maximal inhibitory concentration: 240 nM
Beside the measured number, compound 4's estimate is 1.7-fold (0.22 log units) above it; measured number inside the range.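

In this assay, the change to 3-hydroxy-4-methoxyphenyl now has a readable size, and it is a 3.9-fold lower number from compound 3 to compound 4 (0.59 log units; beyond the scatter) toward stronger inhibition. The earlier pair of compound 1 and compound 2 could give no such size: the limit of > 20000 nM in this assay, at which 2 of the 4 values shown sit.
The hydroxy gain therefore rests on this single pair and holds only for the core of compound 3.

As far as these compounds go, whether an amine, a fluorine or an ethoxy at the same position would match hydroxy stays open. From the compounds shown here alone, whether hydroxy would give a readable step on the core of compound 1 also stays open.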